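A Carboxy Group Gives Way to (2-Chlorophenyl)carbamoyl

This account rests on a few compounds, and the source may have more. Where it says the series, first, only, none or still open, it means among the compounds named here.

In a functional assay on KB cells (Homo sapiens) for inhibition, read by MTT assay, with a stated time of 24 h, tested at 10 ug/mL (a lower number here means less inhibition of growth, a higher number more inhibition of growth at the concentration tested), compound 1 `O=C(O)CCCCC(CCSC(=O)c1ccccc1)SC(=O)c1ccccc1` gives 2.68%, the lower of the two numbers available, and the gap to compound 2 `O=C(CCCCC1CCSS1)Nc1ccc(Br)cn1`, which gives 35.1%, lies beyond the scatter. Compound 3 `O=C(CCCCC(S)CCS)Nc1cccc2ccccc12` is recorded only as "not active" (no number reported), without a number. Compound 4 `O=C(CCCCC(CCSC(=O)c1ccccc1)SC(=O)c1ccccc1)Nc1ccccc1Cl` keeps the core of compound 1 but carries (2-chlorophenyl)amino in place of hydroxy on a carbonyl carbon. Going by the values given here, no measured pair isolates this change. The carboxy group is also absent from compound 2, at 35.1%, and from compound 3, at "not active" (no number reported), so the guidance is mixed. In this assay a moderate rise beyond the scatter is expected, the estimated step being a number 19.3 percentage points higher from compound 1 to compound 4 (beyond the scatter). For compound 4 the expected value is 22%, within an estimated range of 5% to 50%.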

Compound 4, percent growth inhibition at one concentration: 2.53%
Compound 4: middle estimate off by 19.5 percentage points, on the high side; the whole stated range lies above it.
By their numbers in this assay, from the lowest: compounds 4 and 1 (each within the scatter of the next); then compound 2.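

With the core of compound 1 held, the exchange of hydroxy for (2-chlorophenyl)amino on a carbonyl carbon can now be read directly in this assay: the step is a number 0.2 percentage points lower from compound 1 to compound 4 (within the scatter). On this pair, the carboxy group gives way to (2-chlorophenyl)carbamoyl with no step beyond the scatter. Nothing available here explains this result. On these data alone, it remains open whether methoxy or dimethylamino on the same carbonyl carbon would read differently. As far as these compounds go, whether the same exchange would read alike on another core also remains open.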